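From compound 3 to compound 4: one group exchanged

The source may report more compounds than this note shows. Statements on the series, on what has been measured and on what is new or still open speak of the compounds shown alone.

Within the data shown here, in a physicochemical assay for solubility, at pH 7.4 (on this read-out higher numbers stand for higher solubility and lower numbers for lower solubility), compound 3 `C[C@@H]1[C@@H](N(C)C)CN1c1c(F)cc2c(=O)c(C(=O)O)cn(C3CC3)c2c1F` gives 97.1 ug/mL and stands highest of the single numbers, ahead of compound 1 `CN(C)C1(C)CN(c2c(F)cc3c(=O)c(C(=O)O)cn(C4CC4)c3c2F)C1` at 23.6 ug/mL in a gap beyond the usual scatter. Compound 2 `CC1(N)CN(c2c(F)cc3c(=O)c(C(=O)O)cn(C4CC4)c3c2F)C1` has no single number, with entries of 0.8 ug/mL; 15.3 ug/mL (2 entries) in repeated measurements. One of these lies within the scatter of compound 1 and the other well short of it.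

Compound 4 `C[C@H]1N(c2c(F)cc3c(=O)c(C(=O)O)cn(C4CC4)c3c2F)C[C@]1(C)N` departs from compound 3 in one place: a group of 7 heavy atoms (5 carbon, 2 nitrogen; one four-membered non-aromatic ring with 1 hetero atom) in place of a group of 8 heavy atoms (6 carbon, 2 nitrogen; one four-membered non-aromatic ring with 1 hetero atom), on an aromatic carbon, on the aromatic carbon ortho to two fluoro groups. Among the measured compounds shown here, the one measured step nearby, a 4.1-fold higher number from compound 1 to compound 3 (0.61 log units; beyond the scatter), is modest and exchanges a group of the same size. Compound 2 is the closest measured relative of compound 4, so its lower numbers pull the expectation down. In this assay a drop is expected, a 6.5-fold lower number from compound 3 to compound 4 (0.81 log units; beyond the scatter), beyond the scatter but uncertain in size. That expectation stays loose because of the several entries of compound 2 in this assay, 0.8 ug/mL; 15.3 ug/mL (2 entries) for this closest relative. For compound 4 the expected value is 15 ug/mL within an estimated range of 3 ug/mL to 60 ug/mL at this stage.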

Compound 4, solubility: 3.3 ug/mL
For compound 4 the middle estimate is 4.5-fold (0.66 log units) above the measured one; measured number inside the range.
By their numbers in this assay, from the lowest: compound 4; then compound 1; then compound 3.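

In this assay, the earlier step at this aromatic carbon, ortho to two fluoro groups, was modest, whereas this exchange produces a large fall: a 29-fold lower number from compound 3 to compound 4 (1.47 log units; beyond the scatter). Among these compounds, the new group also gives a lower number than the one in the other comparison, a 7.2-fold lower number from compound 1 to compound 4 (0.85 log units; beyond the scatter), so keeping the four-membered ring does not by itself keep the number high. The entering group counts 1 hydrogen-bond donor and the leaving group 0, a difference that accompanies the fall but is not shown to produce it.

From the compounds shown here alone, whether a methylamino group on the same ring would give a number nearer compound 3 or compound 4 remains open. The place of compound 2 as a comparison also stays unsettled: the several entries of compound 2 in this assay, 0.8 ug/mL; 15.3 ug/mL (2 entries)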